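The source may hold more compounds than are shown below. What is called first, only, known or untested is meant among the compounds shown, and "the series" means these compounds.

Working notes on the series.

Compound 2 `CCCn1ccnc1-c1cc(OC)c(OC)c(OC)c1` is examined in a functional assay on HCT-15 cells (Homo sapiens) for antiproliferative activity, read by MTT assay, with a stated time of 72 h; a higher number here means a weaker inhibitor, a lower number a stronger inhibitor. Compound 2 gives > 100000 nM, which is a limit of the assay and not a number. Compound 1 `COc1cc(-c2nccn2C)cc(OC)c1OC` likewise gives > 100000 nM, a limit. Compound 3 `CCCCCn1ccnc1-c1cc(OC)c(OC)c(OC)c1` gives > 100000 nM, again a limit. Thus compound 2 stands at the same limit as the other two measured compounds; the limit of > 100000 nM in this assay, at which 3 of the 3 values shown sit, holds for every value shown, so no ordering among compounds 1, 2 and 3 can be read.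

Compound 4 `COc1ccc(-n2ccnc2-c2cc(OC)c(OC)c(OC)c2)cc1` is not yet measured in this assay. It differs from compound 2 as follows: 4-methoxyphenyl in place of propyl on an aromatic nitrogen

The measured steps that touch the same position are a step that the two limits leave unreadable from compound 1 to compound 2 and a step that the two limits leave unreadable from compound 1 to compound 3; a further step, a step that the two limits leave unreadable from compound 2 to compound 3, lies along the chain. Each of them is unreadable, since both ends sit at the limit, so they give no size and no direction for the change from propyl to 4-methoxyphenyl. Among the measured compounds shown here, the expected step of an at least 20-fold lower number from compound 2 to compound 4 (1.30 log units; beyond the scatter) therefore rests on no measured step and is given with a wide range. For compound 4 the estimated value in this assay is 5000 nM, with a range from 100 nM to 100000 nM, and a substantial chance that only a limit is again reported.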

Compound 4, half-maximal inhibitory concentration: 1300 nM
Beside the measured number, compound 4's estimate is 3.8-fold (0.59 log units) above it, within the range that was stated.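

In this assay, among the compounds shown here, the group on the aromatic nitrogen can move the result, which the earlier compounds could not show: 4-methoxyphenyl in place of propyl gives an at least 76-fold lower number from compound 2 to compound 4 (1.88 log units; beyond the scatter), in place of pentyl gives an at least 76-fold lower number from compound 3 to compound 4 (1.88 log units; beyond the scatter), and in place of methyl gives an at least 76-fold lower number from compound 1 to compound 4 (1.88 log units; beyond the scatter). Compound 1, compound 2 and compound 3 each remain at a limit, so these steps are bounds and not exact sizes: the limit of > 100000 nM in this assay, at which 3 of the 4 values shown sit. The steps among methyl, propyl and pentyl still cannot be read, and of the four groups shown on this nitrogen only 4-methoxyphenyl, the one with a six-membered aromatic ring and a hydrogen-bond acceptor, gives a number and not a limit.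

The compounds shown leave open whether the aromatic ring alone or its methoxy group accounts for the step, a question that an unsubstituted phenyl on the same nitrogen would address. They also leave open how the result responds to other groups on that ring, such as a hydroxyl or a chlorine in place of the methoxy group, or to a benzyl group on the nitrogen.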